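Ester chain variation and antiproliferative activity in the series

This account rests on a few compounds, and the source may have more. Where it says the series, first, only, none or still open, it means among the compounds named here.

Measured so far:
- compound 1 `C/C=C1/[C@H](O[C@@H]2O[C@H](CO)[C@@H](O)[C@H](O)[C@H]2O)OC=C(C(=O)OC)[C@H]1CC(=O)OCCCCCCCCCCCCCCC`: 1600 nM
- compound 2 `C/C=C1/[C@H](O[C@@H]2O[C@H](CO)[C@@H](O)[C@H](O)[C@H]2O)OC=C(C(=O)OC)[C@H]1CC(=O)OCCC`: > 15000 nM (a limit)
- compound 3 `C/C=C1/[C@H](O[C@@H]2O[C@H](CO)[C@@H](O)[C@H](O)[C@H]2O)OC=C(C(=O)O)[C@H]1CC(=O)O`: > 50000 nM (a limit)

In a functional assay on SK-BR-3 cells (Homo sapiens) for antiproliferative activity, read by MTT assay, with a stated time of 72 h (a lower number here means a stronger inhibitor, a higher number a weaker inhibitor), compound 1 gives 1600 nM. Compound 2 reaches only a limit of the assay, > 15000 nM. Compound 3 likewise reaches only a limit, > 50000 nM. Compound 2 therefore stands at the weaker end of the numbers shown, with no measurable value of its own; the one step that reaches it is an at least 9.3-fold higher number from compound 1 to compound 2 (0.97 log units; beyond the scatter), a change from dodecyl to hydrogen on the ester chain.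

Compound 4 `C/C=C1/[C@H](O[C@@H]2O[C@H](CO)[C@@H](O)[C@H](O)[C@H]2O)OC=C(C(=O)OC)[C@H]1CC(=O)OCCc1ccccc1` is not yet measured. Relative to compound 2 the change is phenyl in place of methyl on a saturated chain carbon, two bonds along the chain from an oxygen next to a carbonyl group. Within the data shown here, the only measured step that bears on it is the one from compound 1 to compound 2, where a longer ester chain went with a lower number; the step to compound 4 adds less to the chain than pentadecyl does, and it starts from a value that sits at the limit of > 15000 nM in this assay, at which 1 of the 3 values shown sits, so a downward step of modest size is expected, an at least 1.8-fold lower number from compound 2 to compound 4 (0.27 log units; that floor lies within the scatter), with a fair chance that only a limit is again reported. The estimate for compound 4 in this assay is 8000 nM, within 2500 nM to 30000 nM.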

Compound 4, half-maximal inhibitory concentration: 11000 nM
Beside the measured number, compound 4's estimate is 1.4-fold (0.14 log units) below it; the range from low to high includes it.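

In this assay compound 4 gives a measured value of 11000 nM, which shows that phenyl in place of methyl on a saturated chain carbon, two bonds along the chain from an oxygen next to a carbonyl group, yields a readable number with a short ester chain. The change reads as an at least 1.3-fold lower number from compound 2 to compound 4 (0.13 log units; that floor lies within the scatter), and nothing firmer can be said of its direction or size. That step stays open-ended because compound 2 has only a limit of the assay as its reading: the limit of > 15000 nM in this assay, at which 1 of the 4 values shown sits.

The compounds shown leave open whether the ring itself matters or only the added carbon, a question that a straight octyl chain on the same ester would address. Also open, from the compounds shown here alone, is how a longer chain ending in phenyl, or a phenyl carrying an amine or a carboxylic acid, would read in this assay.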